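The source may hold more compounds than are shown below. What is called first, only, known or untested is meant among the compounds shown, and "the series" means these compounds.

Measured compounds:
Compound 1 `CCC1=C(O)c2c(oc(-c3ccc(CC(C)C)cc3)cc2=O)C(CC)(CC)C1=O` gives 29.3 uM in a functional assay on KB cells (Homo sapiens) for antiproliferative activity, read by sulforhodamine B assay, with a stated time of 3 days; on this read-out higher numbers stand for an effect only at larger amounts of compound and lower numbers for an effect already at smaller amounts.
Compound 2 `CCC1=C(O)c2c(oc(-c3ccc(Br)cc3)cc2=O)C(CC)(CC)C1=O` gives > 48.1 uM in this assay.
Compound 3 `CCC1=C(O)c2c(oc(-c3cc(C)c(OC)cc3C)cc2=O)C(CC)(CC)C1=O` gives 36.6 uM in this assay.

For compound 2 the result is only a limit of this assay, not a number, as noted in the limit of > 48.1 uM in this assay, at which 1 of the 3 values shown sits. Compound 2 therefore sits at the edge of what this assay can report, while compound 1 and compound 3 both give measured numbers that lie within the usual scatter of each other.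

Compound 4 `CCC1=C(O)c2c(oc(-c3cc(C)c(O)c(C)c3)cc2=O)C(CC)(CC)C1=O` has not yet been measured. It differs from compound 2 in one place: 4-hydroxy-3,5-dimethylphenyl in place of 4-bromophenyl on an aromatic carbon.

Among the compounds with values here, the one measured step that bears on this change is bromo in place of isobutyl on an aromatic carbon, which gave an at least 1.6-fold higher number from compound 1 to compound 2 (0.21 log units; that floor lies within the scatter). Going the other way, from the bromo compound to a substituted phenyl carrying carbon and oxygen groups, a return toward measurable numbers is expected, resembling compound 3 rather than compound 2. The expected step is an at least 1.4-fold lower number from compound 2 to compound 4 (0.16 log units; that floor lies within the scatter) in this assay. Compound 4 is therefore estimated at 33 uM, with an expected range from 14 uM to 70 uM.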

Compound 4, concentration for half-maximal effect: 18.3 uM
For compound 4 the middle estimate is 1.8-fold (0.26 log units) above the measured one; low and high end bracket the measured number.
By their numbers in this assay, from the lowest: compounds 4, 1 and 3 (each within the scatter of the next). At a limit, above all of these: compound 2.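

Within the data shown here, replacing 4-bromophenyl with 4-hydroxy-3,5-dimethylphenyl gives an at least 2.6-fold lower number from compound 2 to compound 4 (0.41 log units; beyond the scatter) in this assay, the first step at this position that lies beyond the scatter. The earlier step here, an at least 1.6-fold higher number from compound 1 to compound 2 (0.21 log units; that floor lies within the scatter), could not by itself show that the group at this position changes the result, since its floor lay within the scatter. On these data alone, compound 2 gives only a limit and not a number, so the new step is also a floor and its full size stays unknown: the limit of > 48.1 uM in this assay, at which 1 of the 4 values shown sits.

The hydroxy group and the two methyl groups enter together in compound 4, so the compounds shown cannot separate their contributions. As far as these compounds go, it also remains open how an amine or a carboxylic acid in place of that hydroxy group would read in this assay.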